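A few compounds are considered here, and "the series" means these few. Any claim that something is new, unique, unknown or untested is made for them only; others in the source may bear on it.

Measured so far in a functional assay (Platelet, plasma) for inhibition, with Homo sapiens as the target; a higher number here means a weaker inhibitor, a lower number a stronger inhibitor:
- compound 1 `N#Cc1ccc(CS(=O)(=O)NC(=O)C2CCN(c3nc4c(cc3C#N)C(=O)OC4)CC2)cc1`: 8900 nM
- compound 2 `N#Cc1cc2c(nc1N1CCC(C(=O)NS(=O)(=O)c3ccc(Cl)s3)CC1)COC2=O`: 4470 nM

Compound 2 stands level with compound 1, as the two numbers lie within the scatter of each other. Only these two compounds have been measured, so little can yet be said about what this series can reach.

The next compound, compound 3 `N#Cc1cc2c(nc1N1CCC(C(=O)NS(=O)(=O)Cc3ccc(C(F)(F)F)cc3)CC1)COC2=O`, has 4-(trifluoromethyl)benzyl in place of 5-chlorothiophen-2-yl on a sulfonyl sulfur.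

Going by the values given here, one measured step bears on this change: a 2.0-fold lower number from compound 1 to compound 2 (0.30 log units; within the scatter). That step swapped 4-cyanobenzyl for 5-chlorothiophen-2-yl at the same place, so it is close to the reverse of the new change. Compound 1, whose group is also a substituted benzyl, gives 8900 nM, and this value anchors the expectation. Among the compounds with values here, no measured compound carries 4-(trifluoromethyl)benzyl, so the forecast remains loose.

No shift beyond the scatter is expected in this assay, and the expected change is a 1.3-fold higher number from compound 2 to compound 3 (0.13 log units; within the scatter). For compound 3 the estimated value is 6000 nM, with an expected range from 2000 nM to 18000 nM.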

Compound 3, half-maximal inhibitory concentration: 15900 nM
For compound 3 the middle estimate is 2.7-fold (0.42 log units) below the measured one; low and high end bracket the measured number.
By their numbers in this assay, from the lowest: compounds 2, 1 and 3 (each within the scatter of the next, the first and the last beyond it).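

In this assay, going by these compounds alone, replacing 5-chlorothiophen-2-yl with 4-(trifluoromethyl)benzyl on the sulfonyl sulfur gives a 3.6-fold higher number from compound 2 to compound 3 (0.55 log units; beyond the scatter), the first step at this position to clear the scatter, so what sits on this sulfur can shift the number by a modest but readable amount. The picture is not a simple split between benzyl and thiophene groups: trifluoromethyl in place of cyano on an aromatic carbon gives a 1.8-fold higher number from compound 1 to compound 3 (0.25 log units; within the scatter), and a 2.0-fold lower number from compound 1 to compound 2 (0.30 log units; within the scatter) is also within the scatter, so compound 1 cannot be told apart from either neighbour, and only the two ends of this small series differ. Nothing measured here explains the shift in the number.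

The compounds shown leave open whether the ring itself or the extra carbon link of the benzyl group matters more, a question that a plain phenyl ring or a 5-chlorothiophen-2-ylmethyl group at this place could help to separate. As far as these compounds go, it also remains open whether a different group, such as a short alkyl chain or a pyridine ring, could bring the number lower than that of compound 2, at 4470 nM.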